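The source may hold more compounds than are shown below. What is called first, only, known or untested is meant among the compounds shown, and "the series" means these compounds.

Series of hydroxy-azole carboxamides of trifluoromethyl-substituted anilines, tested in an assay on isolated protein for inhibition of mitogen-activated protein kinase kinase kinase 14 (Homo sapiens), read by ADP-Glo, with a stated time of 60 min, in the presence of a further agent that is not named here; a higher number here means a weaker inhibitor, a lower number a stronger inhibitor. Compound 1 `O=C(Nc1cccc(C(F)(F)F)c1)c1nsnc1O` carries a mono-trifluoromethyl aniline and a hydroxy-thiadiazole amide. Compound 2 `Cn1nnc(O)c1C(=O)Nc1cc(C(F)(F)F)cc(C(F)(F)F)c1` carries the bis-trifluoromethyl aniline and a hydroxy-methyltriazole amide. In this assay compound 1 reaches only the limit of the assay, > 100000 nM, and no number. In this assay compound 2 likewise reaches only the limit, > 100000 nM, and no number. Where compound 2 stands is therefore known only as a limit, and the one further value shown is a limit as well; the picture of the series so far is the limit of > 100000 nM in this assay, at which 2 of the 2 values shown sit.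

Compound 3 `O=C(Nc1cc(C(F)(F)F)cc(C(F)(F)F)c1)c1nonc1O` keeps the bis-trifluoromethyl aniline of compound 2 and changes the amide-bound ring: 4-hydroxy-1,2,5-oxadiazol-3-yl in place of 4-hydroxy-1-methyl-1H-1,2,3-triazol-5-yl on a carbonyl carbon. Going by the values given here, no step between measured compounds is available to weigh this change. Given that compound 1 and compound 2, with two different hydroxy-azoles, both sit at the limit of > 100000 nM in this assay, at which 2 of the 2 values shown sit, no movement beyond the scatter is expected here, and the expected step from compound 2 to compound 3 is a number no higher from compound 2 to compound 3 (the limit leaves the size open). Compound 3 is estimated at 100000 nM, within 30000 nM to 300000 nM, most likely reported as a limit again.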

Compound 3, half-maximal inhibitory concentration: > 100000 nM
Compound 3 was reported as a limit; the forecaster's own chance of this, stated with the estimate: 85%; the middle value lies on the limit itself.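

Going by these compounds alone, compound 2 and compound 3 both stand only as limits in this assay, and no step between them can be read. The compounds shown leave open how the 4-hydroxy-1,2,5-oxadiazol-3-yl and 4-hydroxy-1-methyl-1H-1,2,3-triazol-5-yl amides compare, and whether any hydroxy-azole carboxamide of these trifluoromethyl-substituted anilines gives a readable number in this assay at all.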